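A few compounds are considered here, and "the series" means these few. Any claim that something is new, unique, unknown or untested is made for them only; others in the source may bear on it.

Compound 1 `COc1ccc2c(c1)c(C1CC(c3ccccc3)=NN1C(=O)c1ccc(OC)nc1)cn2C`: 1330 nM
Compound 2 `COc1ccc2c(c1)c(C1CC(c3ccc(Br)cc3)=NN1C(=O)c1ccc(OC)nc1)cn2C`: > 10000 nM

Both compounds were tested in a functional assay on HepG2 cells (Homo sapiens) for inhibition, read by MTT assay, with a stated time of 48 h; on this read-out higher numbers stand for weaker inhibition of growth and lower numbers for stronger inhibition of growth. Compound 2 gives > 10000 nM, which is a limit of the assay and not a number. Compound 3 `COc1ccc(C2=NN(C(=O)c3ccc(OC)nc3)C(c3cn(C)c4ccc(OC)cc34)C2)cc1` differs from compound 2 by one change: methoxy in place of bromo on an aromatic carbon. This puts methoxy in place of bromo on an aromatic carbon. Among the measured compounds shown here, the one measured step that bears on it is an at least 7.5-fold higher number from compound 1 to compound 2 (0.87 log units; beyond the scatter), where bromo replaced hydrogen. Methoxy is neither of those two groups, so compound 3 is expected to fall near compound 1 at 1330 nM, though somewhat higher. An estimated step of an at least 2.8-fold lower number from compound 2 to compound 3 (0.45 log units; beyond the scatter) is therefore expected in this assay, towards stronger inhibition of growth. For compound 3 the estimate is 3500 nM, with an expected range of 1000 nM to 10000 nM.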

Compound 3, concentration for 50% growth inhibition: 230 nM
Compound 3: the middle estimate sits 15-fold (1.18 log units) above what was measured; the measured number lies below the stated range.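

This position is not simply closed to substitution: methoxy on the ring gives a 5.8-fold lower number from compound 1 to compound 3 (0.76 log units; beyond the scatter), towards stronger inhibition of growth. The choice of group matters greatly here, as swapping bromo for methoxy gives an at least 43-fold lower number from compound 2 to compound 3 (1.63 log units; beyond the scatter). Compound 2 stands at a limit and not a number, so that step shows only the smallest possible size: the limit of > 10000 nM in this assay, at which 1 of the 3 values shown sits.

Going by these compounds, whether this gain is special to methoxy stays open. An amine, a hydroxy group or a longer chain such as ethoxy in the same place would help to show how far it extends.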